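From trifluoromethyl to cyano on compound 3

This account rests on a few compounds, and the source may have more. Where it says the series, first, only, none or still open, it means among the compounds named here.

In a functional assay on LNCaP cells (Homo sapiens) for antiproliferative activity, read by propidium iodide staining, with a stated time of 96 h (on this read-out lower numbers stand for stronger inhibition and higher numbers for weaker inhibition), compound 1 (`CC(O)(CSc1cccc(S(F)(F)(F)(F)F)c1)C(=O)Nc1ccc(S(F)(F)(F)(F)F)cc1`) gives 25000 nM while compound 2 (`CC(O)(CSc1cccc(C(F)(F)F)c1)C(=O)Nc1cccc(S(F)(F)(F)(F)F)c1`) gives 12700 nM and compound 3 (`CC(O)(COc1ccc(C(F)(F)F)cc1)C(=O)Nc1cccc(S(F)(F)(F)(F)F)c1`) gives 9600 nM on the same read-out. Compound 3 stands within the scatter of compound 2 and beyond the scatter from compound 1, whose number is higher. Compound 4 (`CC(O)(COc1ccc(C#N)cc1)C(=O)Nc1cccc(S(F)(F)(F)(F)F)c1`) keeps the core of compound 3 and carries cyano in place of trifluoromethyl on an aromatic carbon. Among the compounds with values here, no measured pair isolates this change, so the series offers no direct guide, and no step beyond the scatter is expected in this assay, with a slight lean towards a higher number. The estimate is a 1.3-fold higher number from compound 3 to compound 4 (0.10 log units; within the scatter) for this change. For compound 4 the estimated value is 12000 nM (expected range 5000 nM to 28000 nM).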

Compound 4, half-maximal inhibitory concentration: 30000 nM
For compound 4 the middle estimate is 2.5-fold (0.40 log units) below the measured one; measured number above the stated range.
By their numbers in this assay, from the lowest: compounds 3, 2, 1 and 4 (each within the scatter of the next, the first and the last beyond it).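

In this assay, within the data shown here, the change from 4-(trifluoromethyl)phenyl to 4-cyanophenyl gives the first step read across a single difference: a 3.1-fold higher number from compound 3 to compound 4 (0.49 log units; beyond the scatter). On this aromatic carbon, para to a large group, cyano is therefore not an equivalent replacement for trifluoromethyl on the core of compound 3, although this rests on one pair. Nothing available accounts for the rise in the number. Open, as far as these compounds go, is whether a chlorine atom, a methoxy group or a carboxylic acid on this carbon would read closer to trifluoromethyl or to cyano. Also open, from the compounds shown here alone, is whether the step recurs on the core of compound 2.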